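Swapping bromo for fluoro on compound 3

The source may hold more compounds than are shown below. What is called first, only, known or untested is meant among the compounds shown, and "the series" means these compounds.

Compound 3 `O=C(Nc1ccc(S(=O)(=O)Nc2ccccc2)cc1)c1ccc(Cl)cc1Br` gives the lowest of the two numbers seen so far in a functional assay on HEK293 cells for agonist activity at probable G-protein coupled receptor 27 (Homo sapiens), read by a luciferase reporter and beta-arrestin recruitment, with a stated time of 10 min (a higher number here means that more compound is needed for the effect, a lower number that less compound is needed), where compound 3 reaches 1020 nM. Compound 2 `CN(c1ccccc1)S(=O)(=O)c1ccc(NC(=O)c2ccc(Cl)cc2Cl)cc1` gives 2570 nM in this assay, a gap beyond the usual scatter. Compound 1 `O=C(Nc1ccc(Cl)cc1Cl)c1ccc(S(=O)(=O)Nc2ccccc2)cc1` returns only a limit of this assay, > 100000 nM. The next compound, compound 4 `O=C(Nc1ccc(S(=O)(=O)Nc2ccccc2)cc1)c1ccc(Cl)cc1F`, differs from compound 3 in one spot: fluoro in place of bromo on an aromatic carbon. Among the compounds with values here, no pair of measured compounds shows this kind of change, so its effect cannot be read from the numbers at hand. A step beyond the scatter toward a higher number is expected for compound 4, with real uncertainty about its size. The estimate for compound 4 is 3000 nM, between 700 nM and 15000 nM. The expected step is a 2.9-fold higher number from compound 3 to compound 4 (0.47 log units; beyond the scatter).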

Compound 4, half-maximal effective concentration: 3980 nM
Compound 4: the middle estimate sits 1.3-fold (0.12 log units) below what was measured, within the range that was stated.
By their numbers in this assay, from the lowest: compound 3; then compounds 2 and 4 (each within the scatter of the next). At a limit, above all of these: compound 1.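

Fluoro in place of bromo gives a 3.9-fold higher number from compound 3 to compound 4 (0.59 log units; beyond the scatter) in this assay, the first measured step at this position. The choice of halogen ortho to a large group therefore matters here, and of these two, bromo needs less compound for the effect. Nothing in the data at hand explains this step.

The compounds shown leave open how a methyl group, a methoxy group or an amine would behave at this position. They also leave open whether the same swap would give a similar step elsewhere on the ring.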